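Changing the Amide Nitrogen on a Shared Core

The source may hold more compounds than are shown below. What is called first, only, known or untested is meant among the compounds shown, and "the series" means these compounds.

Compound 3 `COc1cc2c(cc1OC)C(CC(=O)N(C)C)CC2` holds the highest of the three numbers in a functional assay on the whole organism (strain Wistar) for inhibition, with Rattus norvegicus as the target, read by paw edema, with stated times of 60 min and 4 h, at a dose of 100 mg/kg by the oral route (a lower number here means less inhibition, a higher number more inhibition at the dose given (going by the name of the read-out)), giving 35.9%; compound 1 `COc1cc2c(cc1OC)C(CC(N)=O)CC2` gives 31.3% and compound 2 `CNC(=O)CC1CCc2cc(OC)c(OC)cc21` gives 29.7%, and both gaps to compound 3 lie within the scatter. The measured steps of a number 1.6 percentage points lower from compound 1 to compound 2 (within the scatter), a number 4.6 percentage points higher from compound 1 to compound 3 (within the scatter) and a number 6.2 percentage points higher from compound 2 to compound 3 (within the scatter) all stay within the scatter. Compound 4 `CCNC(=O)CC1CCc2cc(OC)c(OC)cc21` differs from compound 3 by ethylamino in place of dimethylamino on a carbonyl carbon. Because the earlier change of a methyl for a hydrogen on an amide-type nitrogen gave only a number 6.2 percentage points higher from compound 2 to compound 3 (within the scatter), no step beyond the scatter is expected here in this assay. Compound 4 is therefore estimated to give 32%, with a range from 24% to 40%, an expected step of a number 3.9 percentage points lower from compound 3 to compound 4 (within the scatter).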

Compound 4, a percentage reported as inhibition, in the whole organism at one dose (the size of the read-out at that dose, not a potency): 26.6%
Compound 4: middle estimate off by 5.4 percentage points, on the high side; measured number inside the range.
By their numbers in this assay, from the lowest: compounds 4, 2, 1 and 3 (each within the scatter of the next).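

In this assay the swap of dimethylamino for ethylamino on the carbonyl carbon, which keeps the same heavy atoms but adds one hydrogen-bond donor, gives a number 9.3 percentage points lower from compound 3 to compound 4 (within the scatter) and stays within the scatter. Extending the methyl on the amide nitrogen to ethyl gives a number 3.1 percentage points lower from compound 2 to compound 4 (within the scatter) and replacing the amide hydrogen with ethyl gives a number 4.7 percentage points lower from compound 1 to compound 4 (within the scatter) and neither leaves the scatter, so all four amides read alike. No measurement shown explains these steps. Going by these compounds, whether a longer chain on the amide nitrogen, such as butyl, or a carboxylic acid in place of the amide would move the number beyond the scatter stays open.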